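This account rests on a few compounds, and the source may have more. Where it says the series, first, only, none or still open, it means among the compounds named here.

Measured compounds:
compound 1, `CN(C)CCn1cnnc1-c1cc(Oc2ccc(NC(=O)Nc3ccc(F)c(Cl)c3)cc2F)ccn1` — 720 nM
compound 2, `CCN(CC)CCn1cnnc1-c1cc(Oc2ccc(NC(=O)Nc3ccc(Cl)c(C(F)(F)F)c3)cc2F)ccn1` — 900 nM
compound 3, `CN(C)CCCn1cnnc1-c1cc(Oc2ccc(NC(=O)Nc3ccc(Cl)c(C(F)(F)F)c3)cc2F)ccn1` — 1400 nM

In a functional assay on HT-29 cells (Homo sapiens) for antiproliferative activity, read by MTT assay, with a stated time of 72 h (on this read-out higher numbers stand for weaker inhibition and lower numbers for stronger inhibition), compound 3 gives 1400 nM, the highest of the three numbers shown. Its nearest neighbour is compound 2, the measured step being a 1.6-fold higher number from compound 2 to compound 3 (0.19 log units; within the scatter). Compound 1 sits furthest from compound 3, yet that gap too is within the scatter, so none of the three can be set apart from the others.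

Compound 4, `CN(C)CCCn1cnnc1-c1cc(Oc2ccc(NC(=O)Nc3ccc(F)c(Cl)c3)cc2F)ccn1`, is reached from compound 3 by a change on the urea side: 3-chloro-4-fluorophenyl in place of 4-chloro-3-(trifluoromethyl)phenyl on an amide-type nitrogen. Among the compounds with values here, no measured step isolates this aryl swap. Compound 1 carries the same 3-chloro-4-fluorophenyl group as compound 4, but it differs from compound 2 and compound 3 in the amine chain as well, so its value can only be read as a loose hint. Within the data shown here, the single measured step, from compound 2 to compound 3, concerns the chain, not the aryl ring, and was within the scatter. Compound 4 is therefore expected to land close to compound 3, the estimated step being a 1.4-fold lower number from compound 3 to compound 4 (0.15 log units; within the scatter), with no change beyond the scatter foreseen. The estimate for compound 4 is 1000 nM, within a range from 400 nM to 2500 nM.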

Compound 4, half-maximal inhibitory concentration: 890 nM
Compound 4: the middle estimate sits 1.1-fold (0.05 log units) above what was measured; measured number inside the range.
By their numbers in this assay, from the lowest: compounds 1, 4, 2 and 3 (each within the scatter of the next).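

In this assay the urea-side swap can now be read on its own, with the amine chain held the same: 3-chloro-4-fluorophenyl in place of 4-chloro-3-(trifluoromethyl)phenyl on an amide-type nitrogen gives (a 1.6-fold lower number from compound 3 to compound 4 (0.20 log units; within the scatter)). With the 3-chloro-4-fluorophenyl group held the same, the chain change, (dimethylamino)methyl in place of dimethylamino, gives (a 1.2-fold higher number from compound 1 to compound 4 (0.09 log units; within the scatter)), so neither change separates its pair of compounds in this read-out. No evidence is at hand that could explain these results.

On these data alone, it remains open whether an unsubstituted phenyl or a pyridine ring on that amide-type nitrogen would move the number beyond the scatter. The same question stands for a morpholine or a piperazine in place of the terminal dimethylamino group.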